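Halogen swap in a series without measurable inhibition

The source may report more compounds than this note shows. Statements on the series, on what has been measured and on what is new or still open speak of the compounds shown alone.

Compound 1 `COc1ccc([C@@H]2c3c(OC)cc(OC)cc3/C(=C/c3ccc(F)cc3)[C@H]2c2cc(OC)cc(OC)c2)cc1` carries a fluoro group; compound 2 `COc1ccc([C@@H]2c3c(OC)cc(OC)cc3/C(=C/c3ccc(Cl)cc3)[C@H]2c2cc(OC)cc(OC)c2)cc1` carries chloro in its place, the difference being (chloro in place of fluoro on an aromatic carbon). In a functional assay on RAW264.7 cells (Mus musculus) for inhibition, with stated times of 2 h and 24 h (a lower number here means a stronger inhibitor, a higher number a weaker inhibitor), compound 1 gives only a limit, > 200000 nM. In this assay compound 2 likewise gives only a limit, > 200000 nM. The step between them is a step that the two limits leave unreadable from compound 1 to compound 2, which rests on (the limit of > 200000 nM in this assay, at which 3 of the 3 values shown sit). Compound 3 `COc1ccc([C@@H]2c3c(OC)cc(OC)cc3C(SCc3ccc(F)cc3)[C@H]2c2cc(OC)cc(OC)c2)cc1` differs from compound 1 in more than one place, so the difference between the two cores is not broken down here. In this assay compound 3 gives only a limit, > 200000 nM. Compound 4 `COc1ccc([C@@H]2c3c(OC)cc(OC)cc3C(SCc3ccc(Cl)cc3)[C@H]2c2cc(OC)cc(OC)c2)cc1` is not yet measured and differs from compound 3 by chloro in place of fluoro on an aromatic carbon, the same change at the same place as that between compound 1 and compound 2. Since every measured compound carrying this change sits at the limit of > 200000 nM in this assay, at which 3 of the 3 values shown sit, no readable size is available to carry over. For compound 4 the step that the limit leaves unreadable from compound 3 to compound 4 is expected. Compound 4 is expected to give 300000 nM in this assay, most probably again only as a limit.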

Compound 4, half-maximal inhibitory concentration: > 200000 nM
Compound 4: a limit, no number (the forecaster's own chance of this, stated with the estimate: 90%); the middle value does not contradict the limit.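

In this assay compound 4 gives only a limit, > 200000 nM. No step can be read from compound 3 to compound 4, as both values are limits: the limit of > 200000 nM in this assay, at which 4 of the 4 values shown sit.

The compounds shown leave open how chloro compares with fluoro, and whether any compound in the series reaches a measurable half-maximal inhibitory concentration in this assay.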